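The source may report more compounds than this note shows. Statements on the series, on what has been measured and on what is new or still open speak of the compounds shown alone.

Within the data shown here, in a functional assay on Jurkat cells (Homo sapiens) for cytotoxicity, read by MTT assay, with a stated time of 72 h (a higher number here means a weaker inhibitor, a lower number a stronger inhibitor), two compounds have numbers so far. Compound 1 `O=C(/C=C/c1ccc(NC(=O)Nc2ccc([N+](=O)[O-])cc2)cc1)NO` gives 90 nM, and compound 2 `COc1ccc(NC(=O)Nc2ccc(CCC(=O)NO)cc2)cc1` gives 2800 nM. Compound 2 therefore stands as the higher of the two numbers, which marks it as the weaker inhibitor, and the gap between them lies beyond the usual scatter of repeated measurements.

Compound 3 `O=C(CCc1ccc(NC(=O)Nc2ccc([N+](=O)[O-])cc2)cc1)NO` comes from compound 2 through a single change, nitro in place of methoxy on an aromatic carbon, para to a large group. A nitro group is also present in compound 1, but that compound differs from compound 2 in more than this one place. Among the measured compounds shown here, no measured pair shows this change on its own, so any forecast rests on thin evidence.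

In this assay a moderate drop in the number is expected, estimated as a 2.8-fold lower number from compound 2 to compound 3 (0.45 log units; beyond the scatter). For the measured compounds named here, the direction of that expectation rests on the only measured nitro compound, compound 1, at 90 nM. For compound 3 the estimated value is 1000 nM, with an expected range from 250 nM to 4000 nM.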

Compound 3, half-maximal inhibitory concentration: 810 nM
Compound 3: middle estimate off by 1.2-fold (0.09 log units), on the high side, within the range that was stated.
By their numbers in this assay, from the lowest: compound 1; then compound 3; then compound 2.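

In this assay, among these compounds, the step from methoxy to nitro on the aromatic carbon para to a large group gives a 3.5-fold lower number from compound 2 to compound 3 (0.54 log units; beyond the scatter), the first reading of a single change at this position, and it shows that the number responds to the group placed there. Compound 3 also links to compound 1 through one change in the other part of the molecule, 2-(hydroxycarbamoyl)ethyl in place of 2-(hydroxycarbamoyl)ethenyl, which gives a 9.0-fold higher number from compound 1 to compound 3 (0.95 log units; beyond the scatter), so the saturated and unsaturated chains also give clearly different numbers when the nitro group is held fixed. No independent measurement here explains why either change shifts the number.

With only methoxy and nitro compared at this position, it remains open where an amine or a carboxylic acid would fall, and whether a longer chain ending in the same hydroxycarbamoyl group would follow either of the two chains shown. On these data alone, it is also open whether the step from methoxy to nitro would be of similar size on a compound carrying 2-(hydroxycarbamoyl)ethenyl.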